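Second methoxy group added to a benzothiazole amide series

This account rests on a few compounds, and the source may have more. Where it says the series, first, only, none or still open, it means among the compounds named here.

Measured compounds:
Compound 1, `O=C(CSc1nc2ccc(NC(=O)c3ccccc3)cc2s1)NCc1ccccc1`, gives 35600 nM.
Compound 2, `COc1ccc(CNC(=O)CSc2nc3ccc(NC(=O)c4ccccc4)cc3s2)cc1`, gives 21200 nM.

Both compounds were tested in a functional assay on MCF7 cells (Homo sapiens) for cytotoxicity, read by MTT assay, with a stated time of 48 h; a higher number here means a weaker inhibitor, a lower number a stronger inhibitor. Compound 2 has the lowest of the two numbers, and its nearest neighbour is compound 1; the two differ by a 1.7-fold lower number from compound 1 to compound 2 (0.23 log units; within the scatter), which means that, on these numbers, compound 2 and compound 1 cannot be told apart.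

Compound 3, `COc1ccc(CNC(=O)CSc2nc3ccc(NC(=O)c4ccccc4OC)cc3s2)cc1`, has not yet been measured. It differs from compound 2 by methoxy in place of hydrogen on an aromatic carbon, on an aromatic carbon of a six-membered aromatic ring of carbon only, ortho to a large group. For the measured compounds named here, the only measured step that bears on this change is the earlier addition of a methoxy group, a 1.7-fold lower number from compound 1 to compound 2 (0.23 log units; within the scatter), which stayed within the scatter. A second methoxy group on a different ring of the shared core is therefore expected to give a step of about a 1.2-fold lower number from compound 2 to compound 3 (0.07 log units; within the scatter) in this assay, that is, no change beyond the scatter. Compound 3 is estimated at 18000 nM, with a range from 7000 nM to 50000 nM.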

Compound 3, half-maximal inhibitory concentration: 9300 nM
For compound 3 the middle estimate is 1.9-fold (0.29 log units) above the measured one; low and high end bracket the measured number.
By their numbers in this assay, from the lowest: compound 3; then compounds 2 and 1 (each within the scatter of the next).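

In this assay, the change from benzoyl to (2-methoxyphenyl)carbonyl, which places a methoxy group on an aromatic carbon ortho to a large group, gives a 2.3-fold lower number from compound 2 to compound 3 (0.36 log units; beyond the scatter). This is the first step among these compounds that lies beyond the scatter: the methoxy group added elsewhere in the molecule gave a 1.7-fold lower number from compound 1 to compound 2 (0.23 log units; within the scatter), so the earlier pair could not show that a methoxy group changes this number at all, whereas this position shows a real, if modest, change. No measurement shown here explains this step.

Going by these compounds, it remains open whether the change is specific to methoxy or would also appear with another group at this place, such as a hydroxyl, a fluorine or an amine, and whether methoxy at other carbons of the same ring would do the same. On these data alone, it is also open whether the step depends on the methoxy group already present in compound 2, as both compounds in this pair carry that group.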